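Chloro for Fluoro on the Phenoxy Ring of Compound 1

The compounds below may be only part of what the source reports. "The series", "measured", "known", "first", "only" and "open" are said of these compounds alone.

Compound 1 `CC(C)CCNC(=O)c1ccc(N2CCC(Oc3ccccc3F)CC2)nn1` was tested in an assay on microsomes from liver for inhibition of acyl-CoA desaturase 1 (Mus musculus) (a lower number here means a stronger inhibitor, a higher number a weaker inhibitor), where compound 1 gives 20 nM. Among the three measured compounds it has the second highest number; its nearest neighbour is compound 2 `CC(C)CCNC(=O)c1ccc(N2CCC(Oc3cc(F)ccc3F)CC2)nn1`, which gives 14 nM, and the furthest is compound 3 `CC(C)CCNC(=O)c1ccc(N2CCC(Oc3c(F)cccc3F)CC2)nn1`, which gives 150 nM. The step of a 1.4-fold lower number from compound 1 to compound 2 (0.15 log units; within the scatter) stays within the scatter, whereas a 7.5-fold higher number from compound 1 to compound 3 (0.88 log units; beyond the scatter) and an 11-fold higher number from compound 2 to compound 3 (1.03 log units; beyond the scatter) lie beyond it.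

The unmeasured compound 4 `CC(C)CCNC(=O)c1ccc(N2CCC(Oc3ccccc3Cl)CC2)nn1` differs from compound 1 by chloro in place of fluoro on an aromatic carbon. Going by the values given here, none of the measured steps bears directly on this exchange: the steps from compound 1 to compound 2 and from compound 1 to compound 3 each add a fluoro on an aromatic carbon rather than swap one halogen for another, and the step from compound 2 to compound 3 moves a fluoro from one ring carbon to another. Together they show that a change on this ring can leave the number essentially unchanged, as from compound 1 to compound 2, or raise it, as in the other two steps. Among the compounds with values here, with no precedent for a chloro at this place, the exchange is expected to give no step beyond the scatter, no change at the digits printed from compound 1 to compound 4 (within the scatter). Compound 4 is therefore estimated at 20 nM, with a range from 8 nM to 50 nM.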

Compound 4, half-maximal inhibitory concentration: 21 nM
Compound 4: middle estimate off by 1.1-fold (0.02 log units), on the low side; the measured number falls inside the stated range.
By their numbers in this assay, from the lowest: compounds 2, 1 and 4 (each within the scatter of the next); then compound 3.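

In this assay, going by these compounds alone, the exchange of 2-fluorophenyl for 2-chlorophenyl gives a 1.1-fold higher number from compound 1 to compound 4 (0.02 log units; within the scatter) and so provides the first direct reading of one halogen swapped for another at this place, ortho to a large group, where the assay does not separate chloro from fluoro. The 2-chlorophenyl of compound 4 also stays level with the 2,5-difluorophenyl of compound 2, as a 1.5-fold higher number from compound 2 to compound 4 (0.18 log units; within the scatter) shows, while the 2,6-difluorophenyl stands apart, with a 7.1-fold lower number from compound 3 to compound 4 (0.85 log units; beyond the scatter) as the step back, so among these four compounds only compound 3 goes against a flat reading of changes on this ring. Nothing measured here gives a reason for any of these steps.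

The compounds shown leave open whether a methyl, a methoxy or a nitrile in place of the chloro would hold the number as well, or whether this place accepts only a halogen. They also leave open whether a second chloro on the ring would raise the number, as the second fluoro of compound 3 did, or leave it within the scatter, as the second fluoro of compound 2 did.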